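A few compounds are considered here, and "the series" means these few. Any claim that something is new, unique, unknown or untested is made for them only; others in the source may bear on it.

Working notes on the series. Among the measured compounds shown here, compound 1 `CCCCCCNc1nc(SCc2ccc(C(F)(F)F)cc2)nc2ccccc12` in a functional assay on MCF7 cells (Homo sapiens) for cytotoxicity, read by MTT assay, with a stated time of 72 h (on this read-out higher numbers stand for weaker inhibition and lower numbers for stronger inhibition), gives 24300 nM and is the only member so far with a read number. Compound 2 `FC(F)(F)c1ccc(CSc2nc(N3CCCCC3)c3ccccc3n2)cc1` is reported in this assay only as a limit, > 50000 nM. Compound 3 `COc1ccccc1Nc1nc(SCc2ccc(C(F)(F)F)cc2)nc2ccccc12` is likewise reported only as a limit, > 50000 nM. Compound 2 thus sits at the limit of > 50000 nM in this assay, at which 2 of the 3 values shown sit, which is where compound 3 also sits, so neither of the two can be placed relative to the other: the step that the two limits leave unreadable from compound 2 to compound 3. Both departures from compound 1 go the same way, in that an at least 2.0-fold higher number from compound 1 to compound 2 (0.31 log units; beyond the scatter) and an at least 2.0-fold higher number from compound 1 to compound 3 (0.31 log units; beyond the scatter).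

Compound 4 `FC(F)(F)c1ccc(CSc2nc(Nc3cccc(C(F)(F)F)c3)c3ccccc3n2)cc1` remains to be measured in this assay. It differs from compound 2 by (3-(trifluoromethyl)phenyl)amino in place of piperidin-1-yl on an aromatic carbon. For the measured compounds named here, two measured steps bear on this. The step from compound 1 to compound 3, which puts 2-methoxyphenyl in place of hexyl on the amine nitrogen, rose out of the readable range, so an arylamine at this position has not yet given a number. The step from compound 2 to compound 3, the same kind of swap at the same carbon, cannot be sized. Compound 4 is therefore expected to stay near the limit, with a step that the limit leaves unreadable from compound 2 to compound 4 essentially flat, and its value is estimated at 60000 nM, within 25000 nM to 150000 nM.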

Compound 4, half-maximal inhibitory concentration: 15300 nM
The estimate for compound 4 lay 3.9-fold (0.59 log units) above the measured number; the measured number lies below the stated range.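

The arylamine at this carbon does not by itself push the series out of the readable range of this assay: (3-(trifluoromethyl)phenyl)amino gives an at least 3.2-fold lower number from compound 2 to compound 4 (0.51 log units; beyond the scatter), and against the other arylamine it gives an at least 3.2-fold lower number from compound 3 to compound 4 (0.51 log units; beyond the scatter), so the outcome depends on which aryl group sits on the nitrogen. Exchanging hexyl for 3-(trifluoromethyl)phenyl on that nitrogen gives a 1.6-fold lower number from compound 1 to compound 4 (0.20 log units; within the scatter), so the linear chain and this aryl group cannot be told apart in this read-out. The first two steps have no exact size, as they start from compounds reported only as a limit: the limit of > 50000 nM in this assay, at which 2 of the 4 values shown sit.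

As far as these compounds go, the two aryl groups differ in both the substituent and where it sits, so it remains open which of these separates compound 3 from compound 4, and a plain phenyl or a 3-methoxyphenyl group on the nitrogen would bear on that. From the compounds shown here alone, compound 2 lacks the hydrogen on the amine nitrogen that compound 4 carries, and it also remains open whether that hydrogen matters, which an N-methyl-N-(3-(trifluoromethyl)phenyl)amino group would address.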